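Chloro for fluoro on the fused core of compound 1

The compounds below may be only part of what the source reports. "The series", "measured", "known", "first", "only" and "open" are said of these compounds alone.

Measured compounds:
compound 1 `O=C(Nc1ccc(Cl)cc1)C(=O)N1CCC(c2ccnc3ccc(F)cc23)CC1` — 15 nM
compound 2 `O=C(Nc1ccc(Cl)cc1F)C(=O)N1CCC(c2ccnc3ccc(F)cc23)CC1` — 7 nM
compound 3 `O=C(Nc1ccc(C(F)(F)F)cc1)C(=O)N1CCC(c2ccnc3ccc(F)cc23)CC1` — 90 nM

All three were measured in an assay on SK-OV-3 cells for inhibition of Indoleamine 2,3-dioxygenase 1 (Homo sapiens); on this read-out lower numbers stand for stronger inhibition and higher numbers for weaker inhibition. Compound 1 stands second highest of the three numbers. Its nearest neighbour is compound 2: a 2.1-fold lower number from compound 1 to compound 2 (0.33 log units; beyond the scatter). The furthest is compound 3: a 6.0-fold higher number from compound 1 to compound 3 (0.78 log units; beyond the scatter). Between the other two, a 13-fold higher number from compound 2 to compound 3 (1.11 log units; beyond the scatter).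

Compound 4 `O=C(Nc1ccc(Cl)cc1)C(=O)N1CCC(c2ccnc3ccc(Cl)cc23)CC1` differs from compound 1 in one place: chloro in place of fluoro on an aromatic carbon. Within the data shown here, every measured step in this set alters the anilide side of the molecule; none touches the fused ring system of the shared core, so no measured step bears directly on this change. The steps seen so far were modest to large, but all sit on the other ring. With nothing to lean on, the expectation for compound 4 in this assay is a step of no more than the scatter, no change at the digits printed from compound 1 to compound 4 (within the scatter), in no preferred direction. Compound 4 is therefore estimated at 15 nM, with a range from 6 nM to 40 nM.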

Compound 4, half-maximal inhibitory concentration: 19 nM
Compound 4: middle estimate off by 1.3-fold (0.10 log units), on the low side; measured number inside the range.
By their numbers in this assay, from the lowest: compound 2; then compounds 1 and 4 (each within the scatter of the next); then compound 3.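

On the fused ring system of the shared core, chloro in place of fluoro gives a 1.3-fold higher number from compound 1 to compound 4 (0.10 log units; within the scatter) in this assay, so at this position the two halogens cannot be told apart on this read-out. This is the first step shown on that ring, and unlike the anilide-side steps, such as a 6.0-fold higher number from compound 1 to compound 3 (0.78 log units; beyond the scatter), it stays within the scatter. No supporting measurement bears on why the two halogens read alike here.

The compounds shown leave open how this position responds to a group other than a halogen, such as methoxy, an amine or a nitrile. Also open, on these data alone, is whether the exchange of fluoro for chloro on the core reads the same when paired with the anilide side of compound 2 or compound 3.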